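The compounds below may be only part of what the source reports. "The series", "measured", "known", "first", "only" and "open" are said of these compounds alone.

Compound 2 `COc1ccc(N/C=C\C(=O)c2nc(-c3ccc(C(F)(F)F)cc3)n3ccccc23)cc1OC` stands at the limit of a functional assay on B16-F10 cells (Mus musculus) for cytotoxicity, read by MTT assay, with a stated time of 48 h (a higher number here means a weaker inhibitor, a lower number a stronger inhibitor), where it gives > 30000 nM, a limit and not a number. Compound 1 `O=C(/C=C\Nc1ccc(F)cc1)c1nc(-c2ccc(F)cc2)n2ccccc12` likewise returns only a limit, > 30000 nM. Compound 3 `O=C(/C=C\Nc1ccc2[nH]ccc2c1)c1nc(-c2ccc(C(F)(F)F)cc2)n2ccccc12` gives 18200 nM. For the measured compounds named here, the one measured step, an at least 1.6-fold lower number from compound 2 to compound 3 (0.21 log units; that floor lies within the scatter), alters the amine side and clears the limit only within the scatter, while the limit of > 30000 nM in this assay, at which 2 of the 3 values shown sit, marks where most of the set rests. Compound 4 `COc1ccc(N/C=C\C(=O)c2nc(-c3ccc(F)cc3)n3ccccc23)cc1OC` differs from compound 2 by fluoro in place of trifluoromethyl on an aromatic carbon. Going by the values given here, no measured step covers this change, and compound 1, which also carries 4-fluorophenyl, shows only a limit. Compound 4 is therefore expected to stay at the limit, with an estimate of 40000 nM (20000 nM to 100000 nM). The expected step that the limit leaves unreadable from compound 2 to compound 4 is no more than scatter.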

Compound 4, half-maximal inhibitory concentration: > 30000 nM
Compound 4 ended at the assay's limit; the forecaster's own chance of this, stated with the estimate: 80%; the middle value does not contradict the limit.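

Compound 4 rests at a limit, as do compound 1 and compound 2, so the steps joining compound 4 to compound 1 and to compound 2 cannot be read: the limit of > 30000 nM in this assay, at which 3 of the 4 values shown sit. From the compounds shown here alone, whether 4-fluorophenyl and 4-(trifluoromethyl)phenyl differ in this assay stays open.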